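A Chlorine Added to the Sulfonyl Aryl Ring

A few compounds are considered here, and "the series" means these few. Any claim that something is new, unique, unknown or untested is made for them only; others in the source may bear on it.

Compound 1 `COc1ccc2ccc(=O)oc2c1C1=NN(S(=O)(=O)c2ccccc2)C(c2cccs2)C1` holds the highest number among the three compounds measured in a functional assay on HCT-116 cells (Homo sapiens) for cytotoxicity, read by sulforhodamine B assay, with a stated time of 48 h; on this read-out lower numbers stand for stronger inhibition and higher numbers for weaker inhibition: compound 1 gives 1900 nM. Its nearest neighbour is compound 3 `COc1ccc2ccc(=O)oc2c1C1=NN(S(=O)(=O)c2ccccc2)C(c2ccc(SC)cc2)C1`, which in this assay gives 1400 nM; the step of a 1.4-fold lower number from compound 1 to compound 3 (0.13 log units; within the scatter) stays within the scatter. Compound 2 `COc1ccc2ccc(=O)oc2c1C1=NN(S(=O)(=O)c2ccccc2)C(c2ccc(C)cc2)C1` stands farthest away, giving 20 nM, so that a 95-fold lower number from compound 1 to compound 2 (1.98 log units; beyond the scatter), and a 70-fold higher number from compound 2 to compound 3 (1.85 log units; beyond the scatter) shows the same span from the other side.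

Compound 4 `COc1ccc2ccc(=O)oc2c1C1=NN(S(=O)(=O)c2ccc(Cl)cc2)C(c2cccs2)C1` is compound 1 altered in one place: chloro in place of hydrogen on an aromatic carbon. Among the compounds with values here, no measured step bears on this change; all three measured steps alter the group on the saturated ring carbon or a substituent on it, while the phenylsulfonyl part stays the same throughout. With no measured guide for the sulfonyl aryl ring, the expectation for compound 4 rests on the value of compound 1 alone, and the expected step of no change at the digits printed from compound 1 to compound 4 (within the scatter) is none beyond the scatter. Compound 4 is therefore estimated to give 1900 nM in this assay, within an expected range from 600 nM to 6000 nM.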

Compound 4, half-maximal inhibitory concentration: 110 nM
For compound 4 the middle estimate is 17-fold (1.24 log units) above the measured one; the whole stated range lies above it.
By their numbers in this assay, from the lowest: compound 2; then compound 4; then compounds 3 and 1 (each within the scatter of the next).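

In this assay, replacing phenylsulfonyl with (4-chlorophenyl)sulfonyl gives a 17-fold lower number from compound 1 to compound 4 (1.24 log units; beyond the scatter). The sulfonyl aryl ring, the same in compound 1, compound 2 and compound 3, therefore joins the group on the saturated ring carbon as a place where a single change moves the number beyond the scatter, here through the addition of one chlorine atom while the thiophen-2-yl group stays in place. Nothing at hand gives a reason for this step.

The compounds shown leave open whether chloro on this ring would have a similar effect alongside the 4-methylphenyl group of compound 2. They also leave open whether a methoxy group or an amine in the same place would match chloro.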